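Taking a Methyl Off an Aromatic Oxygen

The source may hold more compounds than are shown below. What is called first, only, known or untested is meant among the compounds shown, and "the series" means these compounds.

Of the compounds shown here, three built on one shared core have been tested in a functional assay on NCI/ADR-RES cells (Homo sapiens) for inhibition, read by sulforhodamine B assay, with a stated time of 48 h; a lower number here means a stronger inhibitor of growth, a higher number a weaker inhibitor of growth. Compound 3 `COc1cc(-c2nn(-c3cccc(NC(=O)Nc4ccc(Cl)c(C(F)(F)F)c4)c3)cc2-c2ccncc2)ccc1Cl` is the only one to return an actual number: in this assay compound 3 gives 7990 nM. Compound 1 `O=C(Nc1cccc(-n2cc(-c3ccncc3)c(-c3ccc(Cl)c(O)c3)n2)c1)Nc1cccc(C(F)(F)F)c1` reaches only a limit of the method, giving > 32500 nM in this assay. Compound 2 `O=C(Nc1cccc(-n2cc(-c3ccncc3)c(-c3ccc(Cl)c(O)c3)n2)c1)Nc1ccc(Cl)c(Cl)c1` likewise stops at a limit, with > 32500 nM in this assay. The step from compound 1 to compound 2, a step that the two limits leave unreadable from compound 1 to compound 2, therefore cannot be sized. Compound 3 thus stands as the sole readable point, the other two sitting at the limit of > 32500 nM in this assay, at which 2 of the 3 values shown sit.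

Compound 4 `O=C(Nc1cccc(-n2cc(-c3ccncc3)c(-c3ccc(Cl)c(O)c3)n2)c1)Nc1ccc(Cl)c(C(F)(F)F)c1` differs from compound 3 by hydrogen in place of methyl on an oxygen on an aromatic ring, turning methoxy into hydroxy. Going by the values given here, no measured pair makes this same change, so no step gives its size directly. What the data do show is that compound 1 and compound 2, which both carry the hydroxy, sit at a limit, while compound 3 with the methoxy gives a number, though these compounds also differ elsewhere. On that basis compound 4 is expected to be a weaker growth inhibitor, a step of a 2.5-fold higher number from compound 3 to compound 4 (0.40 log units; beyond the scatter), with an estimated value of 20000 nM and a likely range from 8000 nM to 45000 nM, with a fair chance that only a limit is reported.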

Compound 4, concentration for total growth inhibition: 2750 nM
For compound 4 the middle estimate is 7.3-fold (0.86 log units) above the measured one, and the stated range ends above it.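

In this assay, going by these compounds alone, the hydroxy on this aromatic ring does not weaken growth inhibition as the earlier compounds had suggested: replacing methoxy with hydroxy gives a 2.9-fold lower number from compound 3 to compound 4 (0.46 log units; beyond the scatter), a modest step in favour of the free hydroxy. Compound 4 also shows that hydroxy compounds can return a real number, and that the outcome depends strongly on the substituents of the other aromatic ring, with trifluoromethyl in place of chloro giving an at least 11-fold lower number from compound 2 to compound 4 (1.07 log units; beyond the scatter) and chloro in place of hydrogen giving an at least 11-fold lower number from compound 1 to compound 4 (1.07 log units; beyond the scatter). Those two steps are open-ended, as compound 1 and compound 2 each stop at a limit and not at a number: the limit of > 32500 nM in this assay, at which 2 of the 4 values shown sit.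

As far as these compounds go, the methoxy-to-hydroxy step is read here in one pair only, so its size with the other aromatic substitutions of compound 1 and compound 2 remains unknown. Also open, from the compounds shown here alone, is how an amine or an ethoxy group in this same place would compare with the hydroxy of compound 4.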